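Adding chloro to a fluorinated benzamide: an open question

A few compounds are considered here, and "the series" means these few. Any claim that something is new, unique, unknown or untested is made for them only; others in the source may bear on it.

- Compound 1 `O=C(Nc1ccc2c(c1)B(O)OC2)c1ccccc1F`: > 10000 nM (a limit)
- Compound 2 `O=C(Nc1ccc2c(c1)B(O)OC2)c1cccc(C(F)(F)F)c1F`: > 100000 nM (a limit)
- Compound 3 `O=C(Nc1ccc2c(c1)B(O)OC2)c1ccc(C(F)(F)F)cc1F`: > 100000 nM (a limit)

In a functional assay on PBMC cells (Homo sapiens) for inhibition, read by HTRF, with stated times of 15 min and 24 h (on this read-out higher numbers stand for weaker inhibition and lower numbers for stronger inhibition), compound 1 gives > 10000 nM, which is a limit and not a number. On these data alone, its true place on the scale therefore stays open, and compounds 2 and 3 also end at limits rather than numbers.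

Compound 4 `O=C(Nc1ccc2c(c1)B(O)OC2)c1c(F)cccc1Cl` keeps the core of compound 1 and makes one change: chloro in place of hydrogen on an aromatic carbon. The chloro sits on an aromatic carbon, ortho to a large group and meta to a fluoro group.

The nearest measured changes put trifluoromethyl, a different group, in place of hydrogen on compound 1. They give a step that the two limits leave unreadable from compound 1 to compound 2 and a step that the two limits leave unreadable from compound 1 to compound 3. Neither supplies a size or direction to carry over to chloro.

The estimate therefore stays in the neighbourhood of compound 1, with a wide margin, and the assay may again report only a limit. The expected change is an at least 2.0-fold lower number from compound 1 to compound 4 (0.30 log units; that floor lies within the scatter), though even its direction is uncertain. The estimated value for compound 4 is 5000 nM. The expected range runs from 200 nM to 50000 nM.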

Compound 4, half-maximal inhibitory concentration: 3100 nM
Compound 4: the middle estimate sits 1.6-fold (0.21 log units) above what was measured, within the range that was stated.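

In this assay, chloro in place of hydrogen on an aromatic carbon, ortho to a large group and meta to a fluoro group, gives the first readable step among these compounds: an at least 3.2-fold lower number from compound 1 to compound 4 (0.50 log units; beyond the scatter). Since a lower number stands for stronger inhibition, this position can take a chloro group with a gain in inhibition, something the steps that put trifluoromethyl on compound 1 could not show, as those steps cannot be read. The printed step is a floor rather than a full size, because compound 1 ends at a limit and not at a number: the limit of > 10000 nM in this assay, at which 1 of the 4 values shown sits.

The compounds shown cannot tell whether this gain is particular to chloro or would also appear with another group at the same place, such as methyl, methoxy or an amine. Among these compounds, they also leave open whether chloro would give a similar step with the fluoro group replaced by hydrogen, and since compound 4 is the only compound here with a true number, no trend across groups can yet be drawn.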